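A few compounds are considered here, and "the series" means these few. Any claim that something is new, unique, unknown or untested is made for them only; others in the source may bear on it.

Measured so far in a functional assay on T-24 cells (Homo sapiens) for cytotoxicity; on this read-out lower numbers stand for stronger inhibition and higher numbers for weaker inhibition:
compound 1, `CCOC(=O)CCC(=O)NC[C@H]1O[C@@H](n2cc(F)c(=O)[nH]c2=O)C[C@@H]1O` — > 100 ug/mL
compound 2, `O=C(O)CCC(=O)NC[C@H]1O[C@@H](n2cc(F)c(=O)[nH]c2=O)C[C@@H]1O` — 21 ug/mL

Compound 1 reads a limit in this assay, > 100 ug/mL. Among the measured compounds shown here, compound 2 gives 21 ug/mL in this assay, the only plain number so far among the two values shown. The other value, that of compound 1, sits at the limit of > 100 ug/mL in this assay, at which 1 of the 2 values shown sits. For the measured compounds named here, the single measured step, an at least 4.7-fold lower number from compound 1 to compound 2 (0.67 log units; beyond the scatter), is the only move and sits elsewhere in the molecule.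

Compound 3, `O=C(O)/C=C/C(=O)NC[C@H]1O[C@@H](n2cc(F)c(=O)[nH]c2=O)C[C@@H]1O`, is the next one to be measured. It differs from compound 2 by 2-carboxyethenyl in place of 2-carboxyethyl on a carbonyl carbon. Going by the values given here, no measured step touches this part of the chain, so the step from compound 1 to compound 2 gives no direct guide; the expectation rests on compound 2 alone. The step of a 1.2-fold higher number from compound 2 to compound 3 (0.08 log units; within the scatter) is estimated as none beyond the scatter. Compound 3 is therefore expected near 25 ug/mL in this assay, within a range of 8 ug/mL to 80 ug/mL.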

Compound 3, half-maximal inhibitory concentration: 79 ug/mL
Beside the measured number, compound 3's estimate is 3.2-fold (0.50 log units) below it; measured number inside the range.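

In this assay, the chain on the carbonyl carbon matters even with the carboxylic acid kept: 2-carboxyethenyl in place of 2-carboxyethyl gives a 3.8-fold higher number from compound 2 to compound 3 (0.58 log units; beyond the scatter), so this one added double bond moves the number towards weaker inhibition. Set against the ethyl ester chain, the same 2-carboxyethenyl group gives an at least 1.2-fold lower number from compound 1 to compound 3 (0.10 log units; that floor lies within the scatter), which does not place compound 3 apart from compound 1. Compound 1 remains a limit, not a number: the limit of > 100 ug/mL in this assay, at which 1 of the 3 values shown sits.

Still open, from the compounds shown here alone, is how the read-out responds to a longer chain such as 3-carboxypropyl, or to an amine in place of the carboxylic acid. Also open, going by these compounds, is whether the ethyl ester of the 2-carboxyethenyl chain would lose activity as the ethyl ester of the 2-carboxyethyl chain does.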